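Two Cytotoxicity Limits and a Third Compound Awaiting Measurement

This account rests on a few compounds, and the source may have more. Where it says the series, first, only, none or still open, it means among the compounds named here.

Compound 1 `O=C(c1ccncc1)N1N=C(c2cc3ccccc3o2)CC1c1ccccc1[N+](=O)[O-]`: > 245000 nM
Compound 2 `CCn1cc(C(=O)N2N=C(c3cc4ccccc4o3)CC2c2ccc(OC)cc2O)c(=O)c2ccc(C)nc21`: > 154000 nM

Both measured compounds were run in an ADME assay on Vero cells (Chlorocebus sabaeus) for cytotoxicity, read by MTT assay, with a stated time of 72 h; on this read-out lower numbers stand for stronger inhibition and higher numbers for weaker inhibition. Compound 1 gave only a limit, > 245000 nM, and not a number. Compound 2 likewise gave only a limit, > 154000 nM. Among the compounds with values here, compound 2 therefore stands at a limit, as does the one other value shown: the limit of > 154000 nM in this assay, at which 1 of the 2 values shown sits, and the limit of > 245000 nM in this assay, at which 1 of the 2 values shown sits, are the two edges at which these readings sit. Within the data shown here, no step between measured compounds can be given, since neither reading is a number.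

Compound 3 `CCn1cc(C(=O)N2N=C(c3cc4ccccc4o3)CC2/C=C/c2ccccc2)c(=O)c2ccc(C)nc21` differs from compound 2 by 2-phenylethenyl in place of 2-hydroxy-4-methoxyphenyl on a saturated ring carbon. Among the measured compounds shown here, with two limits and no measured step to draw on, the step of an at least 1.0-fold lower number from compound 2 to compound 3 (0.01 log units; that floor lies within the scatter) is expected to be none beyond the scatter, and compound 3 is expected to return a limit as well. The estimate for compound 3 is 150000 nM, with a range from 50000 nM to 300000 nM.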

Compound 3, half-maximal inhibitory concentration: > 168000 nM
Compound 3: a limit, no number (the forecaster's own chance of this, stated with the estimate: 75%); middle value at least 1.1-fold (0.04 log units) away from the limit.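

In this assay compound 3 gives > 168000 nM, a limit and not a number. Within the data shown here, compound 2 gives > 154000 nM, also a limit, so no step between compound 2 and compound 3 can be read. The compounds shown leave open whether 2-phenylethenyl in place of 2-hydroxy-4-methoxyphenyl changes this reading at all.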